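The compounds below may be only part of what the source reports. "The series", "measured", "known", "first", "only" and "open" are said of these compounds alone.

Working notes on the series in a functional assay on MDA-MB-231 cells (Homo sapiens) for antiproliferative activity, read by sulforhodamine B assay, with a stated time of 48 h; on this read-out higher numbers stand for weaker inhibition and lower numbers for stronger inhibition.

Of the compounds shown here, three sharing one core have been measured. Compound 1 `NS(=O)(=O)c1ccc(N/C(S)=N\c2ccnc3cc(C(F)(F)F)ccc23)cc1` gives 52900 nM. Compound 2 `O=S(=O)(Nc1ccccn1)c1ccc(N/C(S)=N\c2ccnc3cc(C(F)(F)F)ccc23)cc1` gives 49300 nM. Compound 3 `O=S(=O)(Nc1ncccn1)c1ccc(N/C(S)=N\c2ccnc3cc(C(F)(F)F)ccc23)cc1` gives 45200 nM. Compound 3 sits together with the other two: the step of a 1.2-fold lower number from compound 1 to compound 3 (0.07 log units; within the scatter) and the step of a 1.1-fold lower number from compound 2 to compound 3 (0.04 log units; within the scatter) are both within the scatter, as is the step of a 1.1-fold lower number from compound 1 to compound 2 (0.03 log units; within the scatter). Across these three compounds, what is attached to the sulfonamide nitrogen has made no difference that the assay resolves.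

Compound 4 `Cc1cc(C)nc(NS(=O)(=O)c2ccc(N/C(S)=N\c3ccnc4cc(C(F)(F)F)ccc34)cc2)n1` is the next variation at the same place: 4,6-dimethylpyrimidin-2-yl in place of pyrimidin-2-yl on a sulfonamide nitrogen. The change adds two methyl groups on the pyrimidin-2-yl ring while keeping the ring and its two nitrogen atoms. All three measured steps bear on it in the sense that they probe the same nitrogen, and each was within the scatter, so the expectation for compound 4 is a step of about a 1.1-fold lower number from compound 3 to compound 4 (0.02 log units; within the scatter), with no direction beyond the scatter. The estimate for compound 4 in this assay is 43000 nM, within the range 20000 nM to 95000 nM.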

Compound 4, half-maximal inhibitory concentration: 52900 nM
Estimate against measurement, compound 4: 1.2-fold (0.09 log units) below; low and high end bracket the measured number.
By their numbers in this assay, from the lowest: compounds 3, 2, 1 and 4 (each within the scatter of the next).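

In this assay, the series stays level even with the larger 4,6-dimethylpyrimidin-2-yl on the sulfonamide nitrogen: all three new steps (a 1.2-fold higher number from compound 3 to compound 4 (0.07 log units; within the scatter)) (a 1.1-fold higher number from compound 2 to compound 4 (0.03 log units; within the scatter)) (no change at the digits printed from compound 1 to compound 4 (within the scatter)) lie within the scatter. Hydrogen, pyridin-2-yl, pyrimidin-2-yl and 4,6-dimethylpyrimidin-2-yl are therefore not told apart at this position, and the two added methyl groups bring no resolved difference. No measurement available here offers an explanation for this result.

The compounds shown leave open whether a group of another kind on this nitrogen, such as an acetyl group, a longer alkyl chain, or a chain ending in a carboxylic acid or an amine, would give a number beyond the scatter. They also leave open whether the number in this assay can be moved from other places on the shared core.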